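Aryl ether variation on the shared core

This account rests on a few compounds, and the source may have more. Where it says the series, first, only, none or still open, it means among the compounds named here.

The series keeps one core and varies the aryl group of a benzyl ether. In an assay on V79MZh11B2 cells for inhibition of cytochrome P450 11B2, mitochondrial (Homo sapiens), read by HPLC, with a stated time of 25 min (on this read-out lower numbers stand for stronger inhibition and higher numbers for weaker inhibition), compound 1 `CC(C)Oc1ccc(COc2ccc3c(Cn4ccnc4)cc(=O)oc3c2)cc1` gives 82 nM. Compound 2 `O=c1cc(Cn2ccnc2)c2ccc(OCc3cccc(Cl)c3)cc2o1` gives 101 nM in this assay, and compound 3 `O=c1cc(Cn2ccnc2)c2ccc(OCc3cc(F)cc(F)c3)cc2o1` gives 200 nM in this assay. Compound 3 thus carries the highest of the three numbers: the step of a 2.0-fold higher number from compound 2 to compound 3 (0.30 log units; within the scatter) stays within the scatter, whereas the gap between compound 1 and compound 3 lies beyond the scatter.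

Compound 4 `COc1ccc(COc2ccc3c(Cn4ccnc4)cc(=O)oc3c2)cc1` is not yet measured. Its difference from compound 3 is 4-methoxyphenyl in place of 3,5-difluorophenyl on a saturated chain carbon bound to an oxygen on an aromatic ring. Within the data shown here, only one measured step touches this position, a 2.0-fold higher number from compound 2 to compound 3 (0.30 log units; within the scatter), and it stays within the scatter. Compound 1 with 82 nM is the closest measured relative of compound 4, and compound 3 sits highest of the three, so a lower number is expected for compound 4. The expected step is a 2.2-fold lower number from compound 3 to compound 4 (0.35 log units; beyond the scatter), downward and beyond the scatter. Compound 4 is therefore estimated at 90 nM in this assay, within 40 nM to 200 nM.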

Compound 4, half-maximal inhibitory concentration: 124 nM
The estimate for compound 4 lay 1.4-fold (0.14 log units) below the measured number, within the range that was stated.
By their numbers in this assay, from the lowest: compounds 1, 2, 4 and 3 (each within the scatter of the next, the first and the last beyond it).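

In this assay there is a 1.6-fold lower number from compound 3 to compound 4 (0.21 log units; within the scatter) and a 1.2-fold higher number from compound 2 to compound 4 (0.09 log units; within the scatter) and a 1.5-fold higher number from compound 1 to compound 4 (0.18 log units; within the scatter) and all three stay within the scatter. Compound 4 thus adds a 4-methoxyphenyl group to this position on a saturated chain carbon bound to an oxygen on an aromatic ring without any listed step beyond the scatter, and methyl in place of isopropyl on an oxygen on an aromatic ring also stays inside it, so among these compounds only the printed values of compound 1 and compound 3 remain beyond the scatter of each other. No measurement offered here accounts for these numbers.

Open, on these data alone, is whether an amine or a carboxylic acid on the aryl group would give a step beyond the scatter. As far as these compounds go, a longer chain in place of the methyl on the ether oxygen, beyond the isopropyl of compound 1, also remains open.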